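The source may report more compounds than this note shows. Statements on the series, on what has been measured and on what is new or still open speak of the compounds shown alone.

The measured compounds are:
compound 1 `COc1ccc2nc(COc3ccc(CC(SSCC(N)C(=O)O)C(=O)O)cc3)n(C)c2c1` with 12.3 ng.h/mL
compound 2 `O=C1NC(=O)C(Cc2ccc(OCc3nc4ccc(O)cc4[nH]3)cc2)S1` with 85.4 ng.h/mL
compound 3 `COc1ccc2nc(COc3ccc(CC(C(N)=O)[S+](C)[O-])cc3)n(C)c2c1` with 36.7 ng.h/mL

All three values come from an ADME assay on the whole organism (plasma) for pharmacokinetics, with Rhesus monkey (Macaca mulatta) as the target, read by LC-MS, at a dose of 1 mg/kg by the oral route; a lower number here means less compound in the circulation, a higher number more compound in the circulation at the dose given. Among them compound 2 stands highest; compound 3 lies nearest to it and compound 1 furthest, and both of those gaps fall beyond the scatter. Compound 4 `Cn1c(COc2ccc(CC3SC(=O)NC3=O)cc2)nc2ccc(O)cc21` has not yet been measured in this assay. It differs from compound 2 in one respect: methyl in place of hydrogen on an aromatic nitrogen. Among the measured compounds shown here, no pair of measured compounds shows this change on its own, so nothing in the three numbers sets its size. The chemist expects a small step in this assay, upward if anything, and probably within the scatter. For compound 4 the chemist estimates 100 ng.h/mL, in the range 35 ng.h/mL to 280 ng.h/mL, which is expected to correspond to a 1.2-fold higher number from compound 2 to compound 4 (0.07 log units; within the scatter).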

Compound 4, area under the concentration-time curve: 310 ng.h/mL
Compound 4: middle estimate off by 3.1-fold (0.49 log units), on the low side, outside the stated range (above it).
By their numbers in this assay, from the lowest: compound 1; then compound 3; then compound 2; then compound 4.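

In this assay, methyl in place of hydrogen on an aromatic nitrogen proves to be no silent change at this position, giving a 3.6-fold higher number from compound 2 to compound 4 (0.56 log units; beyond the scatter). Among the compounds shown here, this is the first step between measured compounds that differ in one place, and it shows that this nitrogen, next to the ring atom that bears a large group, can move the number beyond the scatter. Nothing shown accounts for the step. The compounds leave open whether ethyl or a longer chain on this nitrogen would move the number further, and whether methyl has the same effect when an amine stands elsewhere on the core.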